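A few compounds are considered here, and "the series" means these few. Any claim that something is new, unique, unknown or untested is made for them only; others in the source may bear on it.

Measured compounds:
- compound 1 `COC(=O)/C=C\NC(=O)[C@H](O)C(C)(C)CO`: "not determined" (no result reported)
- compound 2 `CCOC(=O)/C=C/NC(=O)[C@H](O)C(C)(C)CO`: -5%
- compound 3 `CC(C)(CO)[C@H](O)C(=O)N/C=C/C(=O)OCc1ccccc1`: -6%

These three compounds share one core and differ only in the ester group at its end and in the arrangement of the double bond. In an ADME assay on HEK293 cells (Homo sapiens) for inhibition, read by CellTiter-Glo, with a stated time of 96 h, tested at 100 uM (on this read-out higher numbers stand for more inhibition at the one concentration tested (going by the name of the read-out) and lower numbers for less inhibition), compound 2 gives -5%, and in the same assay compound 3 gives -6%. Both numbers sit close to zero and within the usual scatter of each other, so neither shows any inhibition and no order between them can be read. Compound 1 has no single number here, so where it stands in this assay is not known; only the two related esters give a picture.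

Compound 4 `CC(C)(C)OC(=O)/C=C\NC(=O)[C@H](O)C(C)(C)CO` differs from compound 1 in one place: tert-butyl in place of methyl on an oxygen next to a carbonyl group. The change sits on an oxygen next to a carbonyl group whose other neighbours are a carbonyl carbon. Among the measured compounds shown here, no measured pair shows this same change, so its effect in this assay has no direct comparison. Since compound 2 gives -5% and compound 3 gives -6%, the ester group seems to make no difference that rises above scatter, and no step beyond the scatter is expected for compound 4 either. Compound 4 is therefore estimated to give 0%, with a range from -15% to 15%.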

Compound 4, a percentage reported as inhibition, at one concentration (the size of the read-out at that concentration, not a potency): -9%
Beside the measured number, compound 4's estimate is 9 percentage points above it; the range from low to high includes it.
By their numbers in this assay, from the lowest: compounds 4, 3 and 2 (each within the scatter of the next).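

Compound 1 has no single number in this assay, which leaves the change from methyl to tert-butyl in compound 4 without a step that can be read. Nothing measured here gives a reason for the values of these compounds. Still open, going by these compounds, is whether any ester group or double-bond arrangement on the shared core would give real inhibition in this assay.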